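Swapping thiophen-2-yl for pyridin-2-yl in a weak series

The compounds below may be only part of what the source reports. "The series", "measured", "known", "first", "only" and "open" are said of these compounds alone.

In a functional assay on HL-60 cells (Homo sapiens) for cytotoxicity, read by CellTiter-Blue, with a stated time of 48 h (on this read-out higher numbers stand for weaker inhibition and lower numbers for stronger inhibition), compound 1 `CCOC(=O)CC1C(C(=O)OCC)=C(N)Oc2ccc(-c3ccc(F)cc3F)cc21` gives 76600 nM. Compound 2 `CCOC(=O)CC1C(C(=O)OCC)=C(N)Oc2ccc(-c3cccs3)cc21` gives > 80000 nM and this is a limit, not a number. The picture so far therefore includes the limit of > 80000 nM in this assay, at which 1 of the 2 values shown sits, and compound 2 has no exact place on the scale. The next structure, compound 3 `CCOC(=O)CC1C(C(=O)OCC)=C(N)Oc2ccc(-c3ccccn3)cc21`, carries pyridin-2-yl in place of thiophen-2-yl on an aromatic carbon. Going by the values given here, one measured step bears on this change, as it swaps one aromatic ring for another at the same place: an at least 1.0-fold higher number from compound 1 to compound 2 (0.01 log units; that floor lies within the scatter). That step gives only a floor within the scatter, so it fixes neither a size nor a direction, and no step beyond the scatter is expected. The expected change is an at least 1.0-fold lower number from compound 2 to compound 3 (0.02 log units; that floor lies within the scatter). Compound 3 is estimated at 75000 nM with an expected range from 35000 nM to 110000 nM.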

Compound 3, half-maximal inhibitory concentration: 76900 nM
For compound 3 the middle estimate is 1.0-fold (0.01 log units) below the measured one; the measured number falls inside the stated range.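

Replacing 2,4-difluorophenyl with pyridin-2-yl at this place on an aromatic carbon gives, with an exact value on both sides, no change that can be told apart from the scatter in this assay: a 1.0-fold higher number from compound 1 to compound 3 (0.00 log units; within the scatter). Going by these compounds alone, compound 2 remains the one compound whose value is a limit and not a number: the limit of > 80000 nM in this assay, at which 1 of the 3 values shown sits. Its step can therefore be read only as a floor, and that floor gives neither a size nor a direction: an at least 1.0-fold lower number from compound 2 to compound 3 (0.01 log units; that floor lies within the scatter).

All the groups shown at this position are aromatic rings, so it remains open whether a different kind of group here, such as an amine, a carboxylic acid or a longer chain, would give a lower number. Only this one place varies among the compounds shown, so it is also open how changes elsewhere on the shared core would read.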